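This account rests on a few compounds, and the source may have more. Where it says the series, first, only, none or still open, it means among the compounds named here.

Working notes on the series. Compound 3 `C=CCSc1nnc(CC)n1N1C(=O)c2ccccc2C1=O` stands at > 200000 nM in a functional assay on HepG2 cells (Homo sapiens) for cytotoxicity, read by MTT assay, with a stated time of 48 h (a higher number here means a weaker inhibitor, a lower number a stronger inhibitor), which is a limit of the assay and not a number. Compound 2 `C#CCSc1nnc(CC)n1N1C(=O)c2ccccc2C1=O` likewise sits at > 200000 nM, a limit. Compound 1 `Cc1nnc(SCc2ccccc2)n1N1C(=O)c2ccccc2C1=O` also returns > 200000 nM, again a limit. Among the compounds with values here, the sole measured step, a step that the two limits leave unreadable from compound 2 to compound 3, is therefore unreadable, and the limit of > 200000 nM in this assay, at which 3 of the 3 values shown sit, is the only evidence available. Compound 4 `CCc1nnc(SCc2ccccc2)n1N1C(=O)c2ccccc2C1=O` differs from compound 3 by phenyl in place of vinyl on a saturated chain carbon bound to a sulfur. Within the data shown here, no step bears directly on this change; compound 1, which also carries the benzylsulfanyl group, shows only the same limit. No shift beyond the scatter is expected, so the step from compound 3 to compound 4 is estimated as a number no higher from compound 3 to compound 4 (the limit leaves the size open). Compound 4 is accordingly expected to give 200000 nM in this assay, within 100000 nM to 400000 nM.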

Compound 4, half-maximal inhibitory concentration: > 200000 nM
Compound 4: a limit, no number; the forecaster's own chance of this, stated with the estimate: 85%; the middle value sits exactly at the limit.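

In this assay compound 4 gives > 200000 nM, a limit and not a number. The steps to it from compound 1, compound 2 and compound 3 cannot be read. Left open is whether any of these changes shifts the value at all.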